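The source may hold more compounds than are shown below. What is called first, only, known or untested is meant among the compounds shown, and "the series" means these compounds.

Compound 1 `COc1cc2c(cc1OC)CN(CCCCC(=O)c1c(C)c(OC)c(OC)c(OC)c1OC)CC2` gives 160 nM in an assay on membranes from brain for displacement of a labelled ligand from Sigma non-opioid intracellular receptor 1 (Cavia porcellus), read by scintillation counting, with a stated time of 120 min; on this read-out higher numbers stand for weaker inhibition and lower numbers for stronger inhibition. Compound 2 `COc1cc2c(c(OC)c1OC)CCN(CCCCC(=O)c1c(C)c(OC)c(OC)c(OC)c1OC)C2` reaches only the limit of this assay, > 1000 nM. The step of an at least 6.2-fold higher number from compound 1 to compound 2 (0.79 log units; beyond the scatter) accompanies the change (methoxy in place of hydrogen on an aromatic carbon). Compound 3 `COc1cc2c(cc1OC)CN(CCCCCCC(=O)c1c(C)c(OC)c(OC)c(OC)c1OC)CC2` also returns only a limit in this assay, > 1000 nM. How the core of compound 3 differs from the core of compound 1 is not broken down here. Compound 4 `COc1cc2c(c(OC)c1OC)CCN(CCCCCCC(=O)c1c(C)c(OC)c(OC)c(OC)c1OC)C2` has not been measured; it differs from compound 3 by methoxy in place of hydrogen on an aromatic carbon, the same change as that made from compound 1 to compound 2, which occurs twice among these compounds. Compound 4 is expected to show a step that the limit leaves unreadable from compound 3 to compound 4 and most probably to return another limit, because the limit of > 1000 nM in this assay, at which 2 of the 3 values shown sit, and compound 3 already sits there. The estimate for compound 4 is 3000 nM, with a range from 1000 nM to 10000 nM.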

Compound 4, inhibition constant: > 1000 nM
Compound 4 was reported as a limit (the forecaster's own chance of this, stated with the estimate: 85%); the middle value does not contradict the limit.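

Among these compounds, compound 3 and compound 4 both return only a limit in this assay, so no step between them can be read. The compounds shown leave open what methoxy in place of hydrogen on an aromatic carbon does to compound 3.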